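This account rests on a few compounds, and the source may have more. Where it says the series, first, only, none or still open, it means among the compounds named here.

In a functional assay on RS4-11 cells (Homo sapiens) for inhibition, read by CCK-8 assay, with a stated time of 48 h (on this read-out lower numbers stand for stronger inhibition and higher numbers for weaker inhibition), compound 1 `O=S(=O)(NCCNC(=S)Nc1cccc(Cl)c1)c1ccc(-c2ccccc2OCc2ccccc2)s1` gives > 50000 nM as its result, which is a limit of the assay and not a number. Compound 2 `COc1ccc(NC(=O)NCCNS(=O)(=O)c2ccc(-c3ccccc3Oc3ccc([N+](=O)[O-])cc3)s2)cc1` gives > 50000 nM as its result, also a limit. All that can be said so far is the limit of > 50000 nM in this assay, at which 2 of the 2 values shown sit, and no more. Compound 3 `O=[N+]([O-])c1ccc(Oc2ccccc2-c2ccc(S(=O)(=O)NCCNC(=S)Nc3cccc(Cl)c3)s2)cc1` departs from compound 2 in one place, on an amine nitrogen, where the change is a group of 10 heavy atoms (7 carbon, 1 nitrogen, 1 sulfur, 1 chlorine; one six-membered aromatic ring of carbon only) in place of a group of 11 heavy atoms (8 carbon, 1 nitrogen, 2 oxygen; one six-membered aromatic ring of carbon only), on an amine nitrogen and the rest stays the same. The expectation rests on compound 2 at > 50000 nM as a limit. No step beyond the usual scatter is expected, so the estimated change is a number no higher from compound 2 to compound 3 (the limit leaves the size open) in size. For compound 3 the expected value is 50000 nM with an estimated range from 10000 nM to 100000 nM overall.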

Compound 3, half-maximal inhibitory concentration: > 50000 nM
Compound 3 gave a limit, no number (the forecaster's own chance of this, stated with the estimate: 70%); the middle value lies on the limit itself.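

In this assay compound 3 gives > 50000 nM, a limit and not a number. For the compounds shown here, no step from compound 1 or compound 2 to compound 3 can be read. The compounds shown leave open how any single change affects inhibition, with only this to go on: the limit of > 50000 nM in this assay, at which 3 of the 3 values shown sit.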